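Selenocyanate and diselenide carbamates: growth inhibition notes

The compounds below may be only part of what the source reports. "The series", "measured", "known", "first", "only" and "open" are said of these compounds alone.

Measured in an ADME assay on 184B5 cells (Homo sapiens) for cytotoxicity, read by MTT assay, with a stated time of 72 h; on this read-out lower numbers stand for stronger inhibition of growth and higher numbers for weaker inhibition of growth:
- compound 1 `COc1ccc(OC(=O)Nc2ccc([Se]C#N)cc2)cc1` gives 19200 nM
- compound 2 `Cc1ccc(OC(=O)Nc2ccc([Se][Se]c3ccc(NC(=O)Oc4ccc(C)cc4)cc3)cc2)cc1` gives 7600 nM
- compound 3 `O=C(Nc1ccc([Se][Se]c2ccc(NC(=O)Oc3ccc(F)cc3)cc2)cc1)Oc1ccc(F)cc1` gives 8600 nM

Compound 1 stands at the highest of the three numbers, that is, the weakest growth inhibition shown. Compound 3 lies nearest to it with a number lower than that of compound 1, and compound 2 furthest, with a lower number still; both of these gaps fall beyond the usual scatter. Compounds 2 and 3 are within the scatter of each other, so no order between them is claimed. Within the data shown here, compound 1 is the only selenocyanate among the measured set, while compounds 2 and 3 are diselenides of dimeric build; no single-point step between measured compounds exists here.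

Compound 4 `N#C[Se]c1ccc(NC(=O)Oc2ccccc2)cc1` has not yet been measured. It differs from compound 1 in one place: hydrogen in place of methoxy on an aromatic carbon. Among the measured compounds shown here, nothing in the measured set shows what the methoxy contributes, since no pair differing only there has been run in this assay. The change is small in heavy-atom count, and the expectation is a step from compound 1 to compound 4 of a 1.1-fold lower number from compound 1 to compound 4 (0.05 log units; within the scatter), not beyond the scatter in either direction. Compound 4 is therefore estimated at 17000 nM, with a range from 7000 nM to 40000 nM.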

Compound 4, concentration for total growth inhibition: 22700 nM
For compound 4 the middle estimate is 1.3-fold (0.13 log units) below the measured one; measured number inside the range.
By their numbers in this assay, from the lowest: compounds 2 and 3 (each within the scatter of the next); then compounds 1 and 4 (each within the scatter of the next).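

In this assay, among these compounds, the first pair that differs in one place gives a 1.2-fold higher number from compound 1 to compound 4 (0.07 log units; within the scatter), with hydrogen in place of methoxy on an aromatic carbon, para to a large group. This step stays within the scatter, so on this read-out the selenocyanate carbamate keeps its level of growth inhibition without the methoxy, and no order between the two compounds is claimed. Among the compounds shown here, the pair therefore gives a first direct reading at this position, which the earlier compounds could not give, but no measurement at hand bears on why the step is so small.

As far as these compounds go, with only methoxy and hydrogen compared at this place among the selenocyanates, it remains open whether a group such as an amine, a carboxylic acid or trifluoromethyl would also leave the number within the scatter of these two. The compounds shown also leave open how the selenocyanate and diselenide compounds relate, as no pair differing in one place connects compound 1 or compound 4 with compound 2 or compound 3.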